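The compounds below may be only part of what the source reports. "The series", "measured", "known", "first", "only" and "open" are said of these compounds alone.

Measured in a functional assay with Oryctolagus cuniculus as the target; a higher number here means a weaker inhibitor, a lower number a stronger inhibitor:
Compound 1 `COc1ccc(-c2nc(CNC(=O)c3cccnc3)sc2-c2ccc(OC)cc2)cc1`: 25 nM
Compound 2 `COc1ccc(-c2nc(CNC(=O)CSC)sc2-c2ccc(OC)cc2)cc1`: < 100 nM, a limit
Compound 3 `CCN(CC)C(=O)c1nc(-c2ccc(OC)cc2)c(-c2ccc(OC)cc2)s1`: < 10 nM, a limit

Compound 3 has no exact number, only the limit < 10 nM. Among the measured compounds shown here, its position relative to compound 1 is nevertheless clear, since the one readable step is an at least 2.5-fold lower number from compound 1 to compound 3 (0.39 log units; beyond the scatter). That step brought in the diethylcarbamoyl group, in place of the (((pyridin-3-yl)carbonyl)amino)methyl group. The other two steps, a step that the limit leaves unreadable from compound 1 to compound 2 and a step that the two limits leave unreadable from compound 2 to compound 3, offer no size.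

Compound 4 `COc1ccc(-c2nc(C(=O)N=C(N)N)sc2-c2ccc(OC)cc2)cc1` keeps the carbonyl of compound 3 and changes what is attached to it: a group of 4 heavy atoms (1 carbon, 3 nitrogen; no ring) in place of a group of 5 heavy atoms (4 carbon, 1 nitrogen; no ring), on a carbonyl carbon. For the measured compounds named here, no measured step alters the diethylamino group alone, so the evidence is indirect. Compound 4 gives up part of what arrived in an at least 2.5-fold lower number from compound 1 to compound 3 (0.39 log units; beyond the scatter), and a move back toward the level of compound 1, at 25 nM, therefore seems the likelier outcome. A modest rise in the number in this assay is expected, which would mean a weaker inhibitor, with the size uncertain given the limit on the starting point. The expected change is an at least 3.0-fold higher number from compound 3 to compound 4 (0.47 log units; beyond the scatter). For compound 4 the estimated value is 30 nM. The estimated range for compound 4 runs from 5 nM to 200 nM.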

Compound 4, half-maximal inhibitory concentration: > 100 nM
Compound 4: no number, only a limit; the forecaster's own chance of this, stated with the estimate: 35%; middle value at least 3.3-fold (0.52 log units) from the limit.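

In this assay, among the compounds shown here, the carbonyl carbon turns out to be sensitive to what is attached to it: with the carbonyl kept, a group of 4 heavy atoms (1 carbon, 3 nitrogen; no ring) in place of diethylamino gives an at least 10-fold higher number from compound 3 to compound 4 (1.00 log units; beyond the scatter), the first readable change in which diethylamino alone is altered. The new group also falls short of the amide chain bearing pyridin-3-yl, with an at least 4.0-fold higher number from compound 1 to compound 4 (0.60 log units; beyond the scatter), so this change does more than give back the earlier gain and carries the number past the level of compound 1. The remaining step, a number no lower from compound 2 to compound 4 (the limit leaves the size open), cannot be read for size.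

On these data alone, compound 4 has only a limit, > 100 nM, so how far the number rises beyond that point remains open. As far as these compounds go, it also remains open which part of the new group accounts for the loss, and whether another amine on the carbonyl, such as dimethylamino or the longer-chained dipropylamino, would stay close to compound 3 or move toward compound 4.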